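Compound 3 to compound 4: pyridin-3-yl in place of phenyl

The source may report more compounds than this note shows. Statements on the series, on what has been measured and on what is new or still open speak of the compounds shown alone.

- compound 1 `CNc1nc(S(=O)(=O)c2ccc(N)nc2)ccc1-c1ccc(C(C)(O)C(F)(F)F)cn1` gives 21 mL.min-1.g-1 in an ADME assay (liver) for metabolic stability, with Liver microsome (Rattus norvegicus) as the target, using microsomes and NADPH, with a stated time of 30 min, at 37 degrees C, tested at 1 uM; a higher number here means faster removal of the compound, a lower number slower removal
- compound 2 `CC(O)(c1ccc(-c2ccc(S(=O)(=O)c3ccc(N)nc3)nc2NC2CC2)nc1)C(F)(F)F` gives 43 mL.min-1.g-1 in this assay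
- compound 3 `CC(O)(c1ccc(-c2ccc(S(=O)(=O)c3ccc(N)nc3)nc2Nc2ccccc2)nc1)C(F)(F)F` gives 100 mL.min-1.g-1 in this assay

Of these three, compound 3 stands highest at 100 mL.min-1.g-1 in this assay, with compound 2 nearest to it and compound 1 furthest away. The next compound, compound 4 `CC(O)(c1ccc(-c2ccc(S(=O)(=O)c3ccc(N)nc3)nc2Nc2cccnc2)nc1)C(F)(F)F`, keeps the shared core and differs from compound 3 in one group, with pyridin-3-yl in place of phenyl on a nitrogen on an aromatic ring. Three measured steps fall at this same place: a 2.0-fold higher number from compound 1 to compound 2 (0.31 log units; beyond the scatter), a 2.3-fold higher number from compound 2 to compound 3 (0.37 log units; beyond the scatter) and a 4.8-fold higher number from compound 1 to compound 3 (0.68 log units; beyond the scatter). All three are modest and beyond the scatter. None of them exchanges a ring of carbon only for a ring with a hetero atom, so they suggest a likely size for the change but give no direct guide to its direction. Compound 3 at 100 mL.min-1.g-1 already tops the three, so a lower number seems likelier than a higher one, and a modest step is expected. The expected change is a 1.8-fold lower number from compound 3 to compound 4 (0.26 log units; within the scatter). For compound 4 the estimated value is 55 mL.min-1.g-1, with an expected range from 25 mL.min-1.g-1 to 110 mL.min-1.g-1.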

Compound 4, intrinsic clearance in microsomes: 142 mL.min-1.g-1
The estimate for compound 4 lay 2.6-fold (0.41 log units) below the measured number; the measured number lies above the stated range.
By their numbers in this assay, from the lowest: compound 1; then compound 2; then compounds 3 and 4 (each within the scatter of the next).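

In this assay, the exchange of a ring of carbon only for a ring with a hetero atom on this nitrogen gives a 1.4-fold higher number from compound 3 to compound 4 (0.15 log units; within the scatter), so at this position pyridin-3-yl and phenyl cannot be told apart, even though the entering ring adds a ring nitrogen and a hydrogen-bond acceptor. The gap between the aromatic rings and the smaller groups now has a second example, with pyridin-3-yl set against the smaller groups in a 3.3-fold higher number from compound 2 to compound 4 (0.52 log units; beyond the scatter) and in a 6.8-fold higher number from compound 1 to compound 4 (0.83 log units; beyond the scatter), and among these four compounds none goes against the pattern that both aromatic rings give higher numbers than methyl or cyclopropyl. Nothing in the data shown accounts for these results.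

The compounds shown leave open whether pyridin-2-yl or pyridin-4-yl would match pyridin-3-yl here, and whether a saturated ring such as morpholin-4-yl or a short chain such as ethyl would stand with the aromatic rings or with methyl and cyclopropyl. They also leave open whether phenyl bearing a carboxylic acid or an amine would stay with the two aromatic rings.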